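A few compounds are considered here, and "the series" means these few. Any claim that something is new, unique, unknown or untested is made for them only; others in the source may bear on it.

Two measured compounds share one core and differ only in the group attached to the amide carbonyl. In a functional assay on LOX IMVI cells (Homo sapiens) for antiproliferative activity, read by sulforhodamine B assay, with a stated time of 48 h (on this read-out lower numbers stand for stronger inhibition and higher numbers for weaker inhibition), compound 1 `Nc1cccc2c(-c3cccc(NC(=O)c4ccc(Cl)c(C(F)(F)F)c4)c3)ccnc12` gives 3200 nM. Compound 2 `Nc1cccc2c(-c3cccc(NC(=O)c4ccc5c(c4)OCCO5)c3)ccnc12` gives 460 nM, the lowest of the two numbers, with a gap from compound 1 that lies beyond the usual scatter. Compound 3 `Nc1cccc2c(-c3cccc(NC(=O)c4nccs4)c3)ccnc12` changes the group on the carbonyl carbon: 1,3-thiazol-2-yl in place of 2,3-dihydro-1,4-benzodioxin-6-yl on a carbonyl carbon. Going by the values given here, no step of this kind has been measured here, so the expectation is cautious. Compound 3 is expected to show weaker inhibition, a step of a 3.3-fold higher number from compound 2 to compound 3 (0.51 log units; beyond the scatter), with an estimated value of 1500 nM and a likely range from 400 nM to 6000 nM.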

Compound 3, half-maximal inhibitory concentration: 6300 nM
Compound 3: middle estimate off by 4.2-fold (0.62 log units), on the low side, outside the stated range (above it).
By their numbers in this assay, from the lowest: compound 2; then compounds 1 and 3 (each within the scatter of the next).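

In this assay, putting 1,3-thiazol-2-yl in place of 2,3-dihydro-1,4-benzodioxin-6-yl on the carbonyl carbon gives a 14-fold higher number from compound 2 to compound 3 (1.14 log units; beyond the scatter), so the group at this position can strongly change the result. Compound 3 also falls within the scatter of compound 1, so two very different groups can give similar numbers here. No measurement shown explains the size of this step. As far as these compounds go, it remains open whether a plain phenyl ring or a morpholine on the carbonyl carbon would give a number nearer compound 2 or compound 3.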